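This account rests on a few compounds, and the source may have more. Where it says the series, first, only, none or still open, it means among the compounds named here.

Of the compounds shown here, two of a shared core have been measured in a functional assay on MCF7 cells (Homo sapiens) for cytotoxicity, read by MTT assay, with a stated time of 96 h; on this read-out higher numbers stand for weaker inhibition and lower numbers for stronger inhibition. Compound 1 `COc1cc(C(=O)c2cn(-c3ccccc3Cl)cc2-c2ccccc2)cc(OC)c1OC` gives 1800 nM in this assay, and compound 2 `COc1cc(C(=O)c2cn(-c3ccccc3)cc2-c2cccc(Br)c2)cc(OC)c1OC` gives 950 nM. On these two numbers compound 2 stands lowest, though compound 1 lies within the scatter of it, so the two cannot be ordered. Compound 3 `COc1ccc(-c2cn(-c3ccccc3)cc2C(=O)c2cc(OC)c(OC)c(OC)c2)cc1` has not yet been measured in this assay. It differs from compound 2 in one place: 4-methoxyphenyl in place of 3-bromophenyl on an aromatic carbon. Among the measured compounds shown here, no step between measured compounds is available that isolates such a change, so the size of the step from compound 2 to compound 3 in this assay can only be expected, not read off. The expectation is a modest move toward lower numbers, or none beyond the scatter, since the change keeps one six-membered aromatic ring of carbon only at the same place. Compound 3 is therefore expected to give 500 nM in this assay, within a range of 150 nM to 2000 nM, meaning an expected step of a 1.9-fold lower number from compound 2 to compound 3 (0.28 log units; within the scatter).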

Compound 3, half-maximal inhibitory concentration: 70 nM
Compound 3: middle estimate off by 7.1-fold (0.85 log units), on the high side; measured number below the stated range.
By their numbers in this assay, from the lowest: compound 3; then compounds 2 and 1 (each within the scatter of the next).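

In this assay, 4-methoxyphenyl in place of 3-bromophenyl brings a 14-fold lower number from compound 2 to compound 3 (1.13 log units; beyond the scatter), a large step. The earlier compounds shown here gave no step at this position; this one shows that the number depends strongly on the group carried on this aromatic carbon, next to the ring atom that bears a large group. Both groups hold one six-membered aromatic ring of carbon only, so that ring alone does not set the number, and nothing measured here offers an explanation for the size of the step.

The two groups differ both in their substituent and in where it sits on the phenyl ring, and the compounds shown cannot separate these, as 3-methoxyphenyl or 4-bromophenyl would. They also leave open how this position would respond to other groups, such as 4-aminophenyl or 4-ethoxyphenyl.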